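The compounds below may be only part of what the source reports. "The series", "measured", "known", "first", "only" and "open" are said of these compounds alone.

Compound 1 `CCCCCCCCCOc1cccc(N2C(N)=NC(N)=NC2(C)C)c1` gives 6.57 in a functional assay on L5178Y cells (Mus musculus); a higher number here means a more potent compound, by a factor of ten per unit of this negative logarithm, a lower number a less potent compound. Among the measured compounds shown here, the only other measured compound, compound 2 `CCCCCCCCCCCCCOc1cccc(N2C(N)=NC(N)=NC2(C)C)c1`, gives 6.52 in this assay, and the step of a number 0.05 log units lower from compound 1 to compound 2 (within the scatter) leaves the two within the scatter of each other, so neither stands apart. Compound 3 `CC1(C)N=C(N)N=C(N)N1c1cccc(OCCOc2ccccc2)c1` carries the change (phenoxy in place of heptyl on a saturated chain carbon, two bonds along the chain from an oxygen on an aromatic ring). For the measured compounds named here, no measured step tests a ring in place of a chain; the single available step, a number 0.05 log units lower from compound 1 to compound 2 (within the scatter), shows only that a longer chain made no difference beyond the scatter. Compound 3 is therefore expected at 6.4, between 5.8 and 7, a step of a number 0.17 log units lower from compound 1 to compound 3 (within the scatter) that is expected to stay within the scatter.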

Compound 3, logarithm of the reciprocal of the active concentration, log(1/C): 5.02
Beside the measured number, compound 3's estimate is 1.38 log units above it; the measured number lies below the stated range.
By their numbers in this assay, from the lowest: compound 3; then compounds 2 and 1 (each within the scatter of the next).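

Changes at this position are not all equally neutral. In this assay, phenoxy in place of heptyl on the saturated chain carbon gives a number 1.55 log units lower from compound 1 to compound 3 (beyond the scatter), whereas butyl added further along the chain gave only a number 0.05 log units lower from compound 1 to compound 2 (within the scatter). The large loss comes with a group of the same heavy-atom count as heptyl, so that count alone does not preserve the number, and nothing available explains the loss. Going by these compounds, whether it follows the aromatic ring or the added oxygen remains open. A cyclohexyloxy group or a phenyl group at that place could separate the two.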